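From 3-fluorophenyl to 2-hydroxyphenyl: notes on compound 4

The source may report more compounds than this note shows. Statements on the series, on what has been measured and on what is new or still open speak of the compounds shown alone.

In a functional assay on HCT-116 cells (Homo sapiens) for inhibition, with a stated time of 72 h (a higher number here means a weaker inhibitor, a lower number a stronger inhibitor), compound 1 (`NC1CCC(Nc2nc(NCc3ccc(-c4cccc(F)c4)cc3)c3ncn(C4CCCC4)c3n2)CC1`) gives 551 nM and sits in the middle of the three numbers in hand. Compound 2 (`NC1CCC(Nc2nc(NCc3ccc(-c4ccco4)nc3)c3ncn(C4CCCC4)c3n2)CC1`) gives 86 nM on the low side, and compound 3 (`CC(C)(O)CNc1nc(NCc2ccc(-c3ccco3)nc2)c2ncn(C3CCCC3)c2n1`) gives 1270 nM on the high side.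

Compound 4 (`NC1CCC(Nc2nc(NCc3ccc(-c4ccccc4O)cc3)c3ncn(C4CCCC4)c3n2)CC1`) still awaits its number. It carries 2-hydroxyphenyl in place of 3-fluorophenyl on an aromatic carbon, para to a large group (2-hydroxyphenyl in place of 3-fluorophenyl on an aromatic carbon).

Among the compounds with values here, the series offers only one measured step (a 15-fold higher number from compound 2 to compound 3 (1.17 log units; beyond the scatter)) and it is large, but it puts 2-hydroxy-2-methylpropyl in place of 4-aminocyclohexyl on a nitrogen on an aromatic ring. That is not the place changed in compound 4, which keeps 4-aminocyclohexyl, so the size of that step does not carry over. Within the data shown here, the values of compound 1 and compound 2 also lie apart, but those two compounds are not a one-place pair and supply no step. Among the measured compounds shown here, with no measured step at this place, no shift beyond the scatter is expected, and the uncertainty stays wide. In this assay the expected step is a 1.4-fold lower number from compound 1 to compound 4 (0.14 log units; within the scatter) on present evidence. For compound 4 the estimated value is 400 nM with an expected range from 130 nM to 1200 nM for now.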

Compound 4, half-maximal inhibitory concentration: 4350 nM
Estimate against measurement, compound 4: 11-fold (1.04 log units) below, outside the stated range (above it).
By their numbers in this assay, from the lowest: compound 2; then compound 1; then compound 3; then compound 4.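

This position is not indifferent to the group it carries: in this assay 2-hydroxyphenyl in place of 3-fluorophenyl gives a 7.9-fold higher number from compound 1 to compound 4 (0.90 log units; beyond the scatter) with 4-aminocyclohexyl kept in both compounds. Within the data shown here, the earlier compounds offered a measured step only on the nitrogen, where a 15-fold higher number from compound 2 to compound 3 (1.17 log units; beyond the scatter) followed the loss of 4-aminocyclohexyl, so this is the first evidence that the aromatic carbon para to a large group also moves the number beyond the scatter. The exchange leaves the count of 7 heavy atoms and the six-membered aromatic ring of carbon unchanged, and it swaps fluorine for oxygen with 1 hydrogen-bond donor and 1 hydrogen-bond acceptor entering; no measurement in hand bears on the origin of the step.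

The single step changes both the atom and its location on the ring, so the compounds shown cannot separate those two contributions; 2-fluorophenyl, 3-hydroxyphenyl or 2-methoxyphenyl would each bear on that question. They also leave open whether a step of this size would recur in a compound carrying 2-hydroxy-2-methylpropyl on the nitrogen.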